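The source may hold more compounds than are shown below. What is called first, only, known or untested is meant among the compounds shown, and "the series" means these compounds.

Compound 3 `C/N=C(\NC#N)NCCCCn1nc(-c2ccccc2)ccc1=O` gives 32.4 mg/kg in a functional assay on the whole organism (stomach) with Rattus norvegicus as the target (on this read-out lower numbers stand for an effect already at smaller amounts and higher numbers for an effect only at larger amounts of compound), the lowest of the two numbers shown. Compound 1 `N/C(S)=N/CCCCn1nc(-c2ccccc2)ccc1=O` carries a thiourea where compound 3 carries a cyanoguanidine; in this assay compound 1 gives 36.3 mg/kg, and the step of a 1.1-fold lower number from compound 1 to compound 3 (0.05 log units; within the scatter) stays within the scatter. Compound 2 `CCC/N=C(/NC#N)NCCCCn1nc(-c2ccccc2)ccc1=O` reaches only the limit of this assay at > 100 mg/kg. The step of an at least 3.0-fold lower number from compound 2 to compound 3 (0.48 log units; beyond the scatter) is therefore at least modest, with the shorter alkyl on the amine nitrogen giving the lower number (the limit of > 100 mg/kg in this assay, at which 1 of the 3 values shown sits). Compound 4 `CC(C)C/N=C(\S)NCCCCn1nc(-c2ccccc2)ccc1=O` differs from compound 3 by a group of 7 heavy atoms (5 carbon, 1 nitrogen, 1 sulfur; no ring) in place of a group of 6 heavy atoms (3 carbon, 3 nitrogen; no ring), on an amine nitrogen. It joins the thiourea exchange, which was within the scatter, to a branched alkyl larger than that of compound 2, so a higher number is expected, with the step of a 2.5-fold higher number from compound 3 to compound 4 (0.39 log units; beyond the scatter). Compound 4 is estimated at 80 mg/kg, between 30 mg/kg and 200 mg/kg.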

Compound 4, dose for half-maximal effect: > 100 mg/kg
Compound 4: no number, only a limit (the forecaster's own chance of this, stated with the estimate: 40%); middle value at least 1.2-fold (0.09 log units) away from the limit.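

Compound 4 shows that a larger alkyl goes with a higher number on the thiourea as well, not only on the cyanoguanidine. In this assay, the step of an at least 2.7-fold higher number from compound 1 to compound 4 (0.44 log units; beyond the scatter) is at least modest, and so is the step of an at least 3.0-fold higher number from compound 3 to compound 4 (0.48 log units; beyond the scatter). The step between the two limits cannot be read, so the thiourea and the cyanoguanidine cannot be ranked when they carry the larger alkyls: the limit of > 100 mg/kg in this assay, at which 2 of the 4 values shown sit.

On these data alone, it remains open where between a methyl and these larger alkyls the number begins to rise. An ethyl group on either the thiourea or the cyanoguanidine would narrow this.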